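This account rests on a few compounds, and the source may have more. Where it says the series, first, only, none or still open, it means among the compounds named here.

Measured in a functional assay on HCT-116 cells (Homo sapiens) for antiproliferative activity, read by MTT assay, with a stated time of 72 h; on this read-out higher numbers stand for weaker inhibition and lower numbers for stronger inhibition:
- Compound 1 `CCNC(=O)CCc1cccc2c1B(O)OC2`: > 100000 nM, a limit of the assay
- Compound 2 `O=C(CCc1cccc2c1B(O)OC2)Nc1ccccc1`: 350 nM

Within the data shown here, compound 2 holds the only true number in this assay, since the entry for compound 1 is only a limit. Compound 3 `O=C(CCc1cccc2c1B(O)OC2)NCc1ccccc1` carries benzyl in place of phenyl on an amide-type nitrogen. Among the measured compounds shown here, one measured step bears on this place, an at least 280-fold lower number from compound 1 to compound 2 (2.45 log units; beyond the scatter), where phenyl replaced ethyl on the same nitrogen. Benzyl keeps the six-membered aromatic ring that entered in that large step, so a fall all the way back to the limit seems unlikely. For the measured compounds named here, the ring does sit differently on the nitrogen, however, and no measurement yet covers such a change, so some loss is expected. The expected step is a 3.4-fold higher number from compound 2 to compound 3 (0.54 log units; beyond the scatter), towards a higher number. For compound 3 the estimate is 1200 nM, with an expected range of 250 nM to 10000 nM.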

Compound 3, half-maximal inhibitory concentration: > 100000 nM
Compound 3: only a limit was reported; the forecaster's own chance of this, stated with the estimate: 5%; middle value at least 83-fold (1.92 log units) from the limit.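

Benzyl in place of phenyl on an amide-type nitrogen gives an at least 280-fold higher number from compound 2 to compound 3 (2.45 log units; beyond the scatter), a large step for a change from 6 to 7 carbon atoms in the group. Compound 3 keeps the six-membered aromatic ring of compound 2, so that ring alone is not enough for a measurable number here; among the three compounds shown, only the phenyl group on this nitrogen gives one. The step from compound 1 to compound 3 cannot be read, as both entries are limits and not numbers: the limit of > 100000 nM in this assay, at which 2 of the 3 values shown sit.

From the compounds shown here alone, it remains open whether a phenyl ring carrying a fluorine or a methoxy group, or a pyridine ring, would hold the activity of compound 2 on this nitrogen. Going by these compounds, it is also open whether a longer chain, such as phenylethyl, would stay as inactive as benzyl.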